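Replacing a bromophenyl arm in a bis-benzylidene cyclohexanone series

The source may hold more compounds than are shown below. What is called first, only, known or untested is meant among the compounds shown, and "the series" means these compounds.

Measured so far:
Compound 1, `COc1cc(/C=C2\CCC/C(=C\c3cccc(OC)c3OC)C2=O)cc(OC)c1`, 1700 nM
Compound 2, `COc1cc(/C=C2\CCC/C(=C\c3cccc(OC)c3OC)C2=O)ccc1O`, 11600 nM
Compound 3, `COc1ccc(/C=C2\CCC/C(=C\c3cccc(Br)c3)C2=O)cc1OC`, 5300 nM

All three were tested in a functional assay on MCF7 cells (Homo sapiens) for cytotoxicity, read by MTT assay, with a stated time of 72 h; on this read-out higher numbers stand for weaker inhibition and lower numbers for stronger inhibition. Compound 3 stands second highest of the three numbers; compound 2 sits nearest with a higher number, beyond the scatter, and compound 1 furthest with a lower number, also beyond the scatter. The unmeasured compound 4, `COc1cc(/C=C2\CCC/C(=C\c3ccc(OC)c(OC)c3)C2=O)ccc1O`, differs from compound 3 in one place: 4-hydroxy-3-methoxyphenyl in place of 3-bromophenyl on a double-bonded chain carbon bound to a double-bonded ring carbon. Going by the values given here, no step between measured compounds describes this change directly. Compound 2, which carries the same entering group, gives the highest number, so for compound 4 a modest rise in this assay is expected, a 1.5-fold higher number from compound 3 to compound 4 (0.18 log units; within the scatter). Compound 4 is therefore estimated at 8000 nM, within 3000 nM to 22000 nM.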

Compound 4, half-maximal inhibitory concentration: 7900 nM
Beside the measured number, compound 4's estimate is 1.0-fold (0.01 log units) above it; low and high end bracket the measured number.
By their numbers in this assay, from the lowest: compound 1; then compounds 3, 4 and 2 (each within the scatter of the next, the first and the last beyond it).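

In this assay, 4-hydroxy-3-methoxyphenyl in place of 3-bromophenyl on a double-bonded chain carbon bound to a double-bonded ring carbon gives a 1.5-fold higher number from compound 3 to compound 4 (0.17 log units; within the scatter), the only single-place comparison among these compounds. This read-out therefore does not tell the two arms apart, although only the entering one carries a hydrogen-bond donor. No measured evidence bears on why this is so. As far as these compounds go, whether an amine or a carboxylic acid on this arm would move the number beyond the scatter remains open. So does whether the same exchange would read alike with a different second arm on the core.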